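The source may hold more compounds than are shown below. What is called first, only, known or untested is meant among the compounds shown, and "the series" means these compounds.

In a functional assay on HeLa cells (Homo sapiens) for inhibition, read by sulforhodamine B assay (on this read-out higher numbers stand for weaker inhibition and lower numbers for stronger inhibition), three compounds built on a shared core have been measured. Compound 1 `Cc1ccc(NC2=CC(=O)c3c(nc4n3[C@H]3OC[C@@H](O)[C@H]3OC4)C2=O)cc1`, which carries (4-methylphenyl)amino, gives 6590 nM. Compound 2 `O=C1C(N2CCC2)=CC(=O)c2c1nc1n2[C@H]2OC[C@@H](O)[C@H]2OC1` gives > 16000 nM, which is a limit and not a number. Compound 3 `O=C1C(NC2CC2)=CC(=O)c2c1nc1n2[C@H]2OC[C@@H](O)[C@H]2OC1` gives > 16000 nM, also a limit. That places compound 3 at the limit of > 16000 nM in this assay, at which 2 of the 3 values shown sit.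

Compound 4 `O=C1C(NCc2ccccc2)=CC(=O)c2c1nc1n2[C@H]2OC[C@@H](O)[C@H]2OC1` has benzyl in place of cyclopropyl on an amine nitrogen. The most relevant measurement is an at least 2.4-fold higher number from compound 1 to compound 3 (0.38 log units; beyond the scatter), which concerns a change on that same nitrogen. A similar loss appears in an at least 2.4-fold higher number from compound 1 to compound 2 (0.38 log units; beyond the scatter), where azetidin-1-yl is the replacement. The remaining measured step, a step that the two limits leave unreadable from compound 2 to compound 3, offers no guidance. Benzyl brings back a six-membered aromatic ring, as found in compound 1 at 6590 nM, so a modest move toward stronger inhibition is expected. Compound 4 may still stay at the limit. The expected step is an at least 1.4-fold lower number from compound 3 to compound 4 (0.16 log units; that floor lies within the scatter). The estimated value for compound 4 is 11000 nM, with an expected range of 4500 nM to 24000 nM.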

Compound 4, half-maximal inhibitory concentration: 11000 nM
Compound 4: the middle estimate sits on the measured number at the digits printed; low and high end bracket the measured number.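

On this amine nitrogen, benzyl joins 4-methylphenyl as a group that gives a number rather than a limit in this assay, so the aromatic ring need not be attached directly to the nitrogen for a number to be obtained. As far as these compounds go, the steps from the two limit compounds are an at least 1.4-fold lower number from compound 3 to compound 4 (0.16 log units; that floor lies within the scatter) and an at least 1.4-fold lower number from compound 2 to compound 4 (0.16 log units; that floor lies within the scatter), so neither shows a gain beyond the scatter, and their true sizes stay unknown. The remaining step is a 1.7-fold higher number from compound 1 to compound 4 (0.22 log units; within the scatter), so benzyl and 4-methylphenyl cannot be told apart here.

From the compounds shown here alone, how far compound 2 and compound 3 really lie from the others stays open, as each holds only a limit: the limit of > 16000 nM in this assay, at which 2 of the 4 values shown sit. Also open, going by these compounds, is whether a longer chain such as 2-phenylethyl, in place of benzyl on the amine nitrogen, would shift the number beyond the scatter.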